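Cytotoxicity notes: from compound 3 to compound 4

The compounds below may be only part of what the source reports. "The series", "measured", "known", "first", "only" and "open" are said of these compounds alone.

Measured in an ADME assay on Huh-7 cells (Homo sapiens) for cytotoxicity, with a stated time of 3 days; on this read-out higher numbers stand for lower toxicity in this test and lower numbers for higher toxicity in this test:
Compound 1, `O=C(Nc1ccc(F)cc1)c1c(NO)cc(-c2cccs2)oc1=O`: > 20000 nM, a limit of the assay.
Compound 2, `O=C(Nc1ccc(Cl)cc1)c1c(NO)cc(-c2cccs2)oc1=O`: > 20000 nM, a limit of the assay.
Compound 3, `O=C(Nc1ccc(Br)cc1)c1c(NO)cc(-c2cccs2)oc1=O`: > 20000 nM, a limit of the assay.

All three values sit at the limit of > 20000 nM in this assay, at which 3 of the 3 values shown sit. Compound 3 therefore stands only at a limit, as do compound 1 and compound 2. The steps a step that the two limits leave unreadable from compound 1 to compound 2, a step that the two limits leave unreadable from compound 1 to compound 3 and a step that the two limits leave unreadable from compound 2 to compound 3 cannot be read in size or direction.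

Compound 4, `Cc1ccccc1NC(=O)c1c(NO)cc(-c2cccs2)oc1=O`, differs from compound 3 by 2-methylphenyl in place of 4-bromophenyl on an amide-type nitrogen. Within the data shown here, none of the measured steps involves a 2-methylphenyl group, and the three steps that exist give no readable size. No step beyond the scatter is expected in this assay; the step that the limit leaves unreadable from compound 3 to compound 4 is estimated as unreadable, with compound 4 most likely again at the limit. Compound 4 is estimated at 25000 nM, range 10000 nM to 60000 nM.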

Compound 4, half-maximal cytotoxic concentration: > 20000 nM
Compound 4: only a limit was reported; the forecaster's own chance of this, stated with the estimate: 85%; the middle value does not contradict the limit.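

No step from compound 1, compound 2 or compound 3 to compound 4 can be read, since all four stand at one limit: the limit of > 20000 nM in this assay, at which 4 of the 4 values shown sit.

The compounds shown leave open whether any substituent change on the amide-type nitrogen alters cytotoxicity at all.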